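The source may report more compounds than this note shows. Statements on the series, on what has been measured and on what is new or still open speak of the compounds shown alone.

Going by the values given here, in a functional assay on U-373MG ATCC cells (Homo sapiens) for inhibition, read by MTT assay, with a stated time of 72 h (on this read-out higher numbers stand for weaker inhibition and lower numbers for stronger inhibition), three compounds have numbers so far: compound 1 `CC1(C)CC(NC(=O)NCc2ccccc2)c2cc(Br)ccc2O1` gives 27000 nM, compound 2 `CC1(C)CC(NC(=O)NCc2ccccc2)c2cc(Cl)ccc2O1` gives 66000 nM, and compound 3 `CC1(C)CC(NC(=O)Nc2ccc(Cl)cc2)c2cc(Cl)ccc2O1` gives 19000 nM. Compound 2 therefore stands highest of the three, making it the weakest inhibitor here, with both gaps beyond the scatter. Compound 4 `CC1(C)CC(NC(=O)NCc2ccccc2)c2cc(F)ccc2O1` differs from compound 2 at a single place, with fluoro in place of chloro on an aromatic carbon. Among the compounds with values here, the closest precedent is the other halogen swap, a 2.4-fold higher number from compound 1 to compound 2 (0.39 log units; beyond the scatter), where chloro replaces bromo on an aromatic carbon. The remaining step, a 3.5-fold lower number from compound 2 to compound 3 (0.54 log units; beyond the scatter), concerns 4-chlorophenyl in place of benzyl on an amide-type nitrogen, a different place, and says little about this change. A single halogen swap establishes no trend, so the expectation is tentative: a modest further rise in this assay, similar in size to the halogen step and in the same direction. The expected step is a 1.4-fold higher number from compound 2 to compound 4 (0.16 log units; within the scatter). Compound 4 is estimated at 95000 nM, with an expected range from 40000 nM to 220000 nM.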

Compound 4, half-maximal inhibitory concentration: 11000 nM
For compound 4 the middle estimate is 8.6-fold (0.94 log units) above the measured one; the measured number lies below the stated range.
By their numbers in this assay, from the lowest: compounds 4, 3 and 1 (each within the scatter of the next, the first and the last beyond it); then compound 2.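

In this assay fluoro in place of chloro gives a 6.0-fold lower number from compound 2 to compound 4 (0.78 log units; beyond the scatter), and fluoro in place of bromo gives a 2.5-fold lower number from compound 1 to compound 4 (0.39 log units; beyond the scatter), so the halogen swaps at this place do not all run in one direction. Taken with a 2.4-fold higher number from compound 1 to compound 2 (0.39 log units; beyond the scatter), the number rises and then falls along bromo, chloro and fluoro, and among these three benzyl compounds, chloro in compound 2 goes against any steady trend down the halogens. No evidence at hand accounts for this order.

It stays open whether the same order of halogens holds with 4-chlorophenyl on the amide-type nitrogen, a group shown here with chloro only. From the compounds shown here alone, how iodo, methyl, methoxy or a nitrile would read at this place also remains open.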